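The source may hold more compounds than are shown below. What is called first, only, known or untested is meant among the compounds shown, and "the series" means these compounds.

Among the compounds with values here, in a functional assay on the whole organism (Tail, strain ICR) with Mus musculus as the target, in the tail flick test, with a stated time of 60 min, at a dose of 25 umol/kg by the oral route (a lower number here means a weaker effect, a higher number a stronger effect of the compound at the dose given), compound 3 `C[C@@H](O)[C@H](NC(=O)CN(c1nc(Cl)nc2[nH]cnc12)C1CC1)C(=O)OCc1ccccc1` gives 29.7%, the lowest of the three numbers measured so far. Compound 1 `N=C(N)NCCC[C@H](NC(=O)CN(c1nc(Cl)nc2[nH]cnc12)C1CC1)C(=O)O` gives 51%, and compound 2 `CC(C)[C@H](NC(=O)CN(c1nc(Cl)nc2[nH]cnc12)C1CC1)C(=O)OCc1ccccc1` gives 55.5%; both stand beyond the scatter above compound 3. Compound 4 `N=C(N)NCCC[C@H](NC(=O)CN(c1nc(Cl)nc2[nH]cnc12)C1CC1)C(=O)OCc1ccccc1` differs from compound 3 in one place: a group of 7 heavy atoms (4 carbon, 3 nitrogen; no ring) in place of a group of 3 heavy atoms (2 carbon, 1 oxygen; no ring), on a saturated chain carbon bound to an amide-type nitrogen and a carbonyl carbon. Within the data shown here, the one measured step at this position is a number 25.8 percentage points lower from compound 2 to compound 3 (beyond the scatter), which shows that the group on this carbon can shift the read-out by a modest amount. Compound 4 shares its entering group, on the same carbon, with compound 1, which gives 51%, close to compound 2. The expected step is therefore a number 20.3 percentage points higher from compound 3 to compound 4 (beyond the scatter), upward. Compound 4 is estimated at 50%, within 35% to 65%.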

Compound 4, a percentage reported as activity, at one dose (the size of the read-out at that dose, not a potency): 30.6%
Estimate against measurement, compound 4: 19.4 percentage points above; measured number outside the range, below it.
By their numbers in this assay, from the lowest: compounds 3 and 4 (each within the scatter of the next); then compounds 1 and 2 (each within the scatter of the next).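

In this assay, with the benzyl ester kept, the new group in place of 1-hydroxyethyl gives a number 0.9 percentage points higher from compound 3 to compound 4 (within the scatter) on the saturated chain carbon bound to an amide-type nitrogen and a carbonyl carbon, while in place of isopropyl it gives a number 24.9 percentage points lower from compound 2 to compound 4 (beyond the scatter) on that same carbon. The benzyl ester in place of the carboxylic acid gives a number 20.4 percentage points lower from compound 1 to compound 4 (beyond the scatter) with that group held fixed, so the ester end matters as well as the group on this carbon.

From the compounds shown here alone, how an amine at the end of the chain would compare with compound 4 stays open, as does how isopropyl behaves alongside a free carboxylic acid. No measurement available here accounts for these steps.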